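Shortening a Propylamino Chain and Cytotoxicity in Cells

The source may hold more compounds than are shown below. What is called first, only, known or untested is meant among the compounds shown, and "the series" means these compounds.

Within the data shown here, compound 1 `CCCNc1nc(Nc2ccc(C#N)cc2)nc(Oc2ccc3cc(Br)ccc3c2Br)n1` is the only compound with a number in an ADME assay on MT4 cells (Homo sapiens) for cytotoxicity, read by MTT assay, with a stated time of 4 days (a lower number here means that less compound is tolerated, a higher number that more compound is tolerated), where compound 1 gives 134000 nM. Compound 2 `CCCNc1nc(Nc2ccc(C#N)cc2)nc(Oc2ccc3ccccc3c2Br)n1` reaches only a limit of this assay, > 263000 nM. That change, hydrogen in place of bromo on an aromatic carbon, gives an at least 1.9-fold higher number from compound 1 to compound 2 (0.29 log units; that floor lies within the scatter).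

Compound 3 `CNc1nc(Nc2ccc(C#N)cc2)nc(Oc2ccc3cc(Br)ccc3c2Br)n1` differs from compound 1 by hydrogen in place of ethyl on a saturated chain carbon bound to a nitrogen on an aromatic ring. Among the measured compounds shown here, no measured step touches this part of the molecule, so the step from compound 1 to compound 2 concerns a different position. With nothing to point to, a step within the scatter is expected, a 1.1-fold higher number from compound 1 to compound 3 (0.05 log units; within the scatter). Compound 3 is therefore estimated at 150000 nM, between 70000 nM and 300000 nM.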

Compound 3, half-maximal cytotoxic concentration: 92800 nM
Estimate against measurement, compound 3: 1.6-fold (0.21 log units) above; low and high end bracket the measured number.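

Going from propylamino to methylamino gives, in this assay, a 1.4-fold lower number from compound 1 to compound 3 (0.16 log units; within the scatter). This position now has a reading of its own: removing ethyl on the saturated chain carbon bound to a nitrogen on an aromatic ring leaves tolerance in these cells within the usual scatter. Nothing measured here offers a reason for this result. From the compounds shown here alone, whether a longer chain such as butyl, or a carboxylic acid, in this place would give a step beyond the scatter stays open. Among these compounds, also open is how methylamino behaves when the core carries the single bromo of compound 2.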